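Phenyl to Pyridin-2-yl: Expected Effect on Inhibition

This account rests on a few compounds, and the source may have more. Where it says the series, first, only, none or still open, it means among the compounds named here.

Of the compounds shown here, two have been measured in an assay on isolated protein for inhibition of Hematopoietic prostaglandin D synthase (Homo sapiens), read by fluorescence polarization; on this read-out lower numbers stand for stronger inhibition and higher numbers for weaker inhibition. Compound 1 `O=C(NCc1ccccc1)c1ccc(-c2ccccn2)nc1` carries a pyridin-2-yl on the shared core and a simple amide side chain; in this assay compound 1 gives 80.7 nM. Compound 2 `CC(C)(O)c1nc(-c2cccc(CNC(=O)c3ccc(-c4ccccc4)nc3)c2)no1` carries a phenyl on the shared core and a more elaborate amide side chain; in this assay compound 2 gives 27.7 nM. Of the two numbers, that of compound 2 is the lower, and the number of compound 1 lies above it by more than the usual scatter of repeated measurements. Compound 3 `CC(C)(O)c1nc(-c2cccc(CNC(=O)c3ccc(-c4ccccn4)nc3)c2)no1` keeps the amide side chain of compound 2 and alters only the aryl group on the core: pyridin-2-yl in place of phenyl on an aromatic carbon. Among the measured compounds shown here, no pair of measured compounds differs in exactly this way, and compound 1 and compound 2 differ in two places at once, so their gap cannot be attributed to the aryl swap alone. The change is expected to shift the number only a little, in either direction, within the scatter. Compound 3 is therefore estimated at 22 nM, with a range from 9 nM to 55 nM. That estimate means an expected step of a 1.3-fold lower number from compound 2 to compound 3 (0.10 log units; within the scatter).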

Compound 3, half-maximal inhibitory concentration: 55.5 nM
For compound 3 the middle estimate is 2.5-fold (0.40 log units) below the measured one, outside the stated range (above it).
By their numbers in this assay, from the lowest: compounds 2, 3 and 1 (each within the scatter of the next, the first and the last beyond it).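

In this assay, putting pyridin-2-yl in place of phenyl, next to the ring nitrogen and para to a large group, gives a 2.0-fold higher number from compound 2 to compound 3 (0.30 log units; within the scatter), so with this side chain the shared core accepts either aryl group without a change that can be told from the scatter. The other single change can now be read too: with pyridin-2-yl kept on the core, 5-(1-hydroxy-1-methylethyl)-1,2,4-oxadiazol-3-yl in place of hydrogen on an aromatic carbon gives a 1.5-fold lower number from compound 1 to compound 3 (0.16 log units; within the scatter), which also stays within the scatter. Compounds that differed in two places at once could show neither change alone, and now that each has been isolated, neither can be credited with a real effect on this read-out.

No other measurement bears on these two steps, so they remain without an explanation.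
As far as these compounds go, it remains open whether this tolerance extends to a clearly different group at the same place, such as an amine or a carboxylic acid in place of the pyridin-2-yl, and whether the phenyl and pyridin-2-yl pair would behave alike with other amide side chains.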